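The source may hold more compounds than are shown below. What is called first, only, known or untested is meant among the compounds shown, and "the series" means these compounds.

Compound 1, `O=Cc1coc(C(=O)CCCCCCc2ccccc2)n1`: in an assay on HEK-293T cells for inhibition of diacylglycerol lipase-alpha (Homo sapiens), read by colorimetric assay (on this read-out lower numbers stand for stronger inhibition and higher numbers for weaker inhibition), compound 1 gives 1510 nM.
Compound 2, `O=C(CCCCCCc1ccccc1)c1ncno1`: in this assay compound 2 gives only a limit, > 10000 nM.
Compound 3, `CS(=O)(=O)c1cnc(C(=O)CCCCCCc2ccccc2)o1`: in this assay compound 3 gives only a limit, > 10000 nM.

Compound 3 therefore stands at the edge of what this assay can report; its value is a limit rather than a number, and it shares this position with one other compound shown (the limit of > 10000 nM in this assay, at which 2 of the 3 values shown sit). Compound 4, `COc1cnc(C(=O)CCCCCCc2ccccc2)o1`, differs from compound 3 by methoxy in place of methylsulfonyl on an aromatic carbon. Going by the values given here, only one step between measured compounds is available: an at least 6.6-fold higher number from compound 1 to compound 2 (0.82 log units; beyond the scatter). That step exchanges the whole five-membered aromatic ring for a different ring rather than changing a group attached to it, so it speaks only loosely to the present change; it does show that alterations in this part of the molecule can move the read-out well beyond the scatter. Among the compounds with values here, no measured pair exchanges methylsulfonyl for methoxy. Since compound 3 gives only a limit, a downward step of almost any size, or no step at all, would fit what is shown. Compound 4 is expected to remain weak, with an estimated value of 9000 nM spanning 2000 nM to 40000 nM. This corresponds to an expected at least 1.1-fold lower number from compound 3 to compound 4 (0.04 log units; that floor lies within the scatter).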

Compound 4, half-maximal inhibitory concentration: > 10000 nM
Compound 4: a limit, no number (the forecaster's own chance of this, stated with the estimate: 60%); middle value at least 1.1-fold (0.04 log units) from the limit.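

Methoxy in place of methylsulfonyl on this aromatic carbon, next to the ring oxygen, does not bring the read-out back into the range where this assay gives a number, so compound 4 also ends at a limit rather than a value: the limit of > 10000 nM in this assay, at which 3 of the 4 values shown sit. On these data alone, the steps to compound 4 from compound 3 and from compound 2 cannot be read, as each joins two limits, and how compound 3 and compound 4 truly compare remains unknown. Going by these compounds alone, the one readable step is an at least 6.6-fold higher number from compound 1 to compound 4 (0.82 log units; beyond the scatter), which exchanges the whole group on the carbonyl carbon and leaves compound 1, with its 4-formyl-1,3-oxazol-2-yl group, as the only compound here that gives a number.

What the compounds shown leave open is whether any group on this aromatic carbon, such as an amine or a carboxylic acid, would give a measurable value in this assay. Also open, as far as these compounds go, is whether a shorter chain in place of the one shared by all these compounds would change the read-out for either compound 3 or compound 4.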